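The compounds below may be only part of what the source reports. "The series", "measured", "known", "first", "only" and "open" are said of these compounds alone.

The measured compounds:
compound 1, `CC(C)C1CC(=O)c2s/c(=N/c3ccccc3)oc2C1`, 2190 nM in a functional assay on PC-3 cells (Homo sapiens) for antiproliferative activity, read by sulforhodamine B assay; a lower number here means a stronger inhibitor of growth, a higher number a weaker inhibitor of growth
compound 2, `CC(C)C1CC(=O)c2s/c(=N/C3CCCCC3)oc2C1`, 5160 nM in this assay
compound 3, `CC1(C)CC(=O)c2s/c(=N/c3c(Cl)cc(Cl)cc3Cl)oc2C1`, > 30000 nM in this assay

Compound 3 gives no number in this assay, only a limit: the limit of > 30000 nM in this assay, at which 1 of the 3 values shown sits. Compound 1 and compound 2 sit at the lower end of the values shown, and compound 3 stands apart from both at the limit.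

Compound 4, `CC1CC(=O)c2s/c(=N/c3c(Cl)cc(Cl)cc3Cl)oc2C1`, differs from compound 3 in one place: hydrogen in place of methyl on a saturated ring carbon. For the measured compounds named here, the only measured step, a 2.4-fold higher number from compound 1 to compound 2 (0.37 log units; beyond the scatter), concerns the group on the double-bonded nitrogen, not the saturated ring, so it does not bear directly on this change; it only shows that a single substituent swap moved the number modestly. Removing one methyl is a smaller change than that swap, so no step beyond the scatter is expected here. Compound 4 is therefore expected to remain weak, around 40000 nM, within 15000 nM to 100000 nM. The expected step is a step that the limit leaves unreadable from compound 3 to compound 4, most likely reported again only as a limit.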

Compound 4, concentration for 50% growth inhibition: > 30000 nM
Compound 4 gave a limit, no number; the forecaster's own chance of this, stated with the estimate: 70%; the middle value does not contradict the limit.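

Compound 3 and compound 4 each give only a limit in this assay, not a number, so no step between them can be read: the limit of > 30000 nM in this assay, at which 2 of the 4 values shown sit.

The compounds shown leave open whether hydrogen in place of methyl on a saturated ring carbon changes growth inhibition at all.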